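This account rests on a few compounds, and the source may have more. Where it says the series, first, only, none or still open, it means among the compounds named here.

Measured so far:
Compound 1, `COc1ccc(-c2cc(C(=O)Nc3ccc(Oc4ccnc5cc(OCCCN6CCCCC6)c(OC)cc45)c(F)c3)c3ccccc3n2)cc1`, in a functional assay on MKN-45 cells (Homo sapiens) for cytotoxicity, read by MTT assay, with a stated time of 72 h (a lower number here means a stronger inhibitor, a higher number a weaker inhibitor), gives 210 nM.
Compound 2, `COc1cccc(-c2cc(C(=O)Nc3ccc(Oc4ccnc5cc(OCCCN6CCCCC6)c(OC)cc45)c(F)c3)c3ccccc3n2)c1`, in this assay gives 360 nM.

Compound 2 holds the higher of the two numbers, yet its separation from compound 1, a 1.7-fold higher number from compound 1 to compound 2 (0.23 log units; within the scatter), is within the scatter, so the two cannot be ordered. Compound 3, `COc1cccc(-c2cc(C(=O)Nc3ccc(Oc4ccnc5cc(OCCCN6CCCCC6)c(OC)cc45)c(F)c3)c3cc(F)ccc3n2)c1`, is derived from compound 2 by fluoro in place of hydrogen on an aromatic carbon. Going by the values given here, the one measured step, from compound 1 to compound 2, alters the methoxyphenyl group and leaves the fused core untouched, so it gives no guidance for a fluoro placed on that core. Among the compounds with values here, with no measured step bearing on this change, the expectation for compound 3 is a number close to that of compound 2, with a step of no change at the digits printed from compound 2 to compound 3 (within the scatter) and nothing beyond the scatter. Compound 3 is therefore estimated at 360 nM, expected to fall between 120 nM and 1100 nM.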

Compound 3, half-maximal inhibitory concentration: 690 nM
Compound 3: middle estimate off by 1.9-fold (0.28 log units), on the low side; measured number inside the range.
By their numbers in this assay, from the lowest: compounds 1, 2 and 3 (each within the scatter of the next, the first and the last beyond it).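

Going by these compounds alone, this is the first change on the fused part of the shared core, and it replaces a hydrogen with a single fluoro on an aromatic carbon. In this assay the result is a 1.9-fold higher number from compound 2 to compound 3 (0.28 log units; within the scatter), so at this position the fluoro gives no change that can be told apart from ordinary repeat variation, and compound 2 and compound 3 cannot be ordered. Nothing measured here offers an explanation of this result.

From the compounds shown here alone, it remains open whether a chloro, methyl or methoxy group on this same aromatic carbon would also stay within the scatter or would shift the number clearly. Going by these compounds, it is also open whether the fluoro would give a similar result when paired with the 4-methoxyphenyl group of compound 1.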